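A few compounds are considered here, and "the series" means these few. Any claim that something is new, unique, unknown or untested is made for them only; others in the source may bear on it.

Compound 1 `O=C(Nc1cccc(-c2oc3cc(-c4ccc(F)cc4)ccc3c(=O)c2O)c1)c1ccc(Cl)cc1` is the reference point of this small set. In a functional assay on HepG2 cells (Homo sapiens) for antiproliferative activity, read by CCK-8 assay, with a stated time of 72 h (a lower number here means a stronger inhibitor, a higher number a weaker inhibitor), compound 1 gives 11000 nM, the lowest of the three numbers measured. Compound 2 `CCc1ccc(C(=O)Nc2cccc(-c3oc4cc(-c5ccc(F)cc5)ccc4c(=O)c3O)c2)cc1` gives 20600 nM and compound 3 `COc1cc(OC)cc(C(=O)Nc2cccc(-c3oc4cc(-c5ccc(F)cc5)ccc4c(=O)c3O)c2)c1` gives 23500 nM. The step of a 1.9-fold higher number from compound 1 to compound 2 (0.27 log units; within the scatter) lies within the scatter, while the step of a 2.1-fold higher number from compound 1 to compound 3 (0.33 log units; beyond the scatter) is modest but beyond it; the step of a 1.1-fold higher number from compound 2 to compound 3 (0.06 log units; within the scatter) is within the scatter.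

Compound 4 `Cc1cc(C)cc(C(=O)Nc2cccc(-c3oc4cc(-c5ccc(F)cc5)ccc4c(=O)c3O)c2)c1` differs from compound 1 in one place: 3,5-dimethylphenyl in place of 4-chlorophenyl on a carbonyl carbon. For the measured compounds named here, two measured steps bear on this change, as both also replace the 4-chlorophenyl of compound 1 on the carbonyl carbon and both gave higher numbers, a 1.9-fold higher number from compound 1 to compound 2 (0.27 log units; within the scatter) and a 2.1-fold higher number from compound 1 to compound 3 (0.33 log units; beyond the scatter). The 3,5-dimethylphenyl resembles the 3,5-dimethoxyphenyl of compound 3 and the 4-ethylphenyl of compound 2, so a modest rise in number is expected for compound 4, a 1.6-fold higher number from compound 1 to compound 4 (0.21 log units; within the scatter). Compound 4 is therefore estimated at 18000 nM, with a range from 9000 nM to 36000 nM.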

Compound 4, half-maximal inhibitory concentration: 13400 nM
Compound 4: the middle estimate sits 1.3-fold (0.13 log units) above what was measured; the measured number falls inside the stated range.
By their numbers in this assay, from the lowest: compounds 1, 4, 2 and 3 (each within the scatter of the next, the first and the last beyond it).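

In this assay, the 3,5-dimethylphenyl of compound 4 on the carbonyl carbon cannot be told apart from the 4-chlorophenyl of compound 1 (a 1.2-fold higher number from compound 1 to compound 4 (0.09 log units; within the scatter)), so this replacement of the chlorine-bearing ring leaves the number within the scatter. Nor can it be told apart from the other two groups at this place (a 1.8-fold lower number from compound 3 to compound 4 (0.24 log units; within the scatter); a 1.5-fold lower number from compound 2 to compound 4 (0.19 log units; within the scatter)), so compound 4 stands within the scatter of compound 1 and of compound 3, although those two lie just beyond the scatter of each other. Nothing available here explains these steps.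

All four groups at this place are phenyl rings carrying chloro, ethyl, methyl or methoxy, and their numbers span a narrow range. Going by these compounds, whether a ring bearing an amine or a carboxylic acid, or a longer chain in place of the ring, would move the number further stays open.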